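Aryl ether variation in a weakly active amine oxidase series

A few compounds are considered here, and "the series" means these few. Any claim that something is new, unique, unknown or untested is made for them only; others in the source may bear on it.

Measured compounds:
compound 1 `C#CCOc1ccc(-c2cc(-c3ccc(OCC#C)c(OC)c3)nc(N)n2)cc1` — "not active" (no number reported)
compound 2 `C#CCOc1ccc(-c2cc(-c3ccc(OCC#C)c(OCC)c3)nc(C)n2)cc1` — "not active" (no number reported)
compound 3 `C#CCOc1ccc(-c2cc(-c3ccc(OCC#C)cc3)nc(N)n2)cc1` — 32100 nM

In an assay on BTI-TN-5B1-4 cells for inhibition of Amine oxidase [flavin-containing] A (Homo sapiens), read by fluorescence and Amplex Red, using microsomes, with a stated time of 30 min (on this read-out higher numbers stand for weaker inhibition and lower numbers for stronger inhibition), compound 3 gives 32100 nM, the only numerical result among the three measured compounds. Compound 1 is reported as "not active" (no number reported) in this assay. Compound 2 is likewise reported as "not active" (no number reported) in this assay. Compound 3 therefore stands alone with a measured half-maximal inhibitory concentration, and that number sits at the weak end of what this assay reports; the other two entries give no number at all.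

Compound 4 `C#CCOc1ccc(-c2cc(-c3ccc(OCC#C)c(OCC)c3)nc(N)n2)cc1` is not yet measured. It differs from compound 3 by ethoxy in place of hydrogen on an aromatic carbon. For the measured compounds named here, no step between two measured compounds is available, so the size of this change can only be guessed. Since two of the three measured compounds return no number in this assay, and compound 3 itself is weak, the expectation for compound 4 is a step toward weaker inhibition, or none beyond the usual scatter, with a real chance of no number being reported. Compound 4 is expected to give about 60000 nM, with a range from 20000 nM to 200000 nM. The expected step of a 1.9-fold higher number from compound 3 to compound 4 (0.27 log units; within the scatter) is estimated to run toward weaker inhibition.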

Compound 4, half-maximal inhibitory concentration: "not active" (no number reported)
Nothing numeric was reported for compound 4, so the estimate cannot be set against anything.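

In this assay, for the compounds shown here, compound 4 is reported as "not active" (no number reported), so no step from compound 3 can be read. The compounds shown leave open whether ethoxy in place of hydrogen changes inhibition at all, and by how much. No measured evidence here bears on this result.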